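Propyl versus Ethyl Carbamate on a Selenocyanate Core

The source may report more compounds than this note shows. Statements on the series, on what has been measured and on what is new or still open speak of the compounds shown alone.

compound 1 `CCCOC(=O)Nc1ccc([Se]C#N)cc1` — in an ADME assay on 184B5 cells (Homo sapiens) for cytotoxicity, read by MTT assay, with a stated time of 72 h (on this read-out higher numbers stand for weaker inhibition of growth and lower numbers for stronger inhibition of growth), compound 1 gives 3700 nM
compound 2 `O=C(Nc1ccc([Se][Se]c2ccc(NC(=O)OCc3ccc([N+](=O)[O-])cc3)cc2)cc1)OCc1ccc([N+](=O)[O-])cc1` — in this assay compound 2 gives 6000 nM

Of the compounds shown here, two have been measured so far. Compound 1 carries a propoxy carbamate on the shared core beside the selenocyanate; compound 2 is the diselenide dimer with nitrobenzyl carbamates at both ends. Compound 1 holds the lower of the two numbers, but compound 2 lies within the scatter of it, so the two values show no order between them. The pair differs in more than one place. No single-step comparison is available from them.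

Compound 3 `CCOC(=O)Nc1ccc([Se]C#N)cc1` is the next member, differing from compound 1 by hydrogen in place of methyl on a saturated chain carbon, two bonds along the chain from an oxygen next to a carbonyl group. A shortening of the chain by one methyl is a small change, and the expectation in this assay is no step beyond the scatter in either direction, with at most a slight rise toward weaker inhibition. Compound 3 is therefore expected to give about 4000 nM, with a likely range from 1800 nM to 9000 nM. The expected step of a 1.1-fold higher number from compound 1 to compound 3 (0.03 log units; within the scatter) is estimated to stay within the scatter.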

Compound 3, concentration for 50% growth inhibition: 5500 nM
For compound 3 the middle estimate is 1.4-fold (0.14 log units) below the measured one; the measured number falls inside the stated range.
By their numbers in this assay, from the lowest: compounds 1, 3 and 2 (each within the scatter of the next).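

Propoxy to ethoxy is the first change in the series that can be read at a single place, and in this assay it gives a 1.5-fold higher number from compound 1 to compound 3 (0.17 log units; within the scatter). On the shared core, hydrogen in place of methyl on this saturated chain carbon, two bonds along the chain from an oxygen next to a carbonyl group, therefore does not separate the two selenocyanates on this read-out, and no order can be drawn between them. No accompanying measurement bears on this result, so the step stands as a bare observation without an explanation.

Whether a longer chain such as butoxy, or a chain ending in an amine or a carboxylic acid, would carry the number beyond the scatter remains open, since the two chains shown cover only a narrow stretch of this position. Compound 2 differs from compound 1 and compound 3 in more than one place, so steps to it cannot be read, and a diselenide bearing a propoxy or ethoxy carbamate would be needed to compare that form with the selenocyanate at a single place.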